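A few compounds are considered here, and "the series" means these few. Any claim that something is new, unique, unknown or untested is made for them only; others in the source may bear on it.

Measured in a functional assay on A549 cells (Homo sapiens) for inhibition, read by colorimetric assay and sulforhodamine B assay, with a stated time of 48 h; a lower number here means a stronger inhibitor of growth, a higher number a weaker inhibitor of growth:
- Compound 1 `CCCCCCCCCCCC[C@@H](O)[C@H]1CC[C@H]([C@H](O)CCCCCCCCCCNC(=O)c2cccs2)O1`: 3720 nM
- Compound 2 `CCCCCCCCCCCC[C@@H](O)[C@H]1CC[C@H]([C@H](O)CCCCCCCCCCNC(=O)c2ccoc2)O1`: 100000 nM
- Compound 3 `CCCCCCCCCCCC[C@@H](O)[C@H]1CC[C@H]([C@H](O)CCCCCCCCCCNC(=O)c2cncs2)O1`: 34700 nM

Compound 3 holds the middle place among these three values. Compound 4 `CCCCCCCCCCCC[C@@H](O)[C@H]1CC[C@H]([C@H](O)CCCCCCCCCCNC(=O)c2ccsc2)O1` has thiophen-3-yl in place of 1,3-thiazol-5-yl on a carbonyl carbon. Among the compounds with values here, two measured steps bear on this change. Within the data shown here, the closest guide is compound 1, the only measured compound with a thiophene-named group, which shows a 9.3-fold higher number from compound 1 to compound 3 (0.97 log units; beyond the scatter), a modest step. Compound 2 adds a caution: a 27-fold higher number from compound 1 to compound 2 (1.43 log units; beyond the scatter) is a large step, so changing this ring can move the number far. A modest move to a lower number is therefore expected, an estimated 4.3-fold lower number from compound 3 to compound 4 (0.64 log units; beyond the scatter). For compound 4 the expected value is 8000 nM, with an estimated range of 2500 nM to 30000 nM.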

Compound 4, concentration for 50% growth inhibition: 100000 nM
Estimate against measurement, compound 4: 13-fold (1.10 log units) below, and the stated range ends below it.
By their numbers in this assay, from the lowest: compound 1; then compound 3; then compounds 2 and 4 (each within the scatter of the next).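

In this assay the two thiophene-named groups do not behave alike on this carbonyl carbon, with a 27-fold higher number from compound 1 to compound 4 (1.43 log units; beyond the scatter) for thiophen-3-yl in place of thiophen-2-yl. Thiophen-3-yl also shows a 2.9-fold higher number from compound 3 to compound 4 (0.46 log units; beyond the scatter) and no change at the digits printed from compound 2 to compound 4 (within the scatter) for the change from furan-3-yl. Among these four compounds, the thiophene ring alone therefore does not secure the number of compound 1, and thiophen-2-yl stands apart from the other three groups.

As far as these compounds go, whether a phenyl ring or a methyl-substituted thiophen-2-yl on this carbonyl carbon would match compound 1 stays open. No measurement shown here explains these steps.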